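Swapping benzyl for 4-bromophenyl on a shared core

This account rests on a few compounds, and the source may have more. Where it says the series, first, only, none or still open, it means among the compounds named here.

Compound 1 `c1ccc(Cc2nnc(Cn3nnc4ccccc43)o2)cc1` has been tested in an ADME assay on cells (Macrophage, Homo sapiens) for inhibition (on this read-out lower numbers stand for higher toxicity in this test and higher numbers for lower toxicity in this test), where compound 1 gives > 100000 nM, which is a limit of the assay and not a number. Compound 2 `Clc1cccc(Cc2nnc(Cn3nnc4ccccc43)o2)c1` differs from compound 1 by a chloro in place of hydrogen on an aromatic carbon. In this assay compound 2 gives > 100000 nM, again a limit. The step that the two limits leave unreadable from compound 1 to compound 2 cannot be sized because of the limit of > 100000 nM in this assay, at which 2 of the 2 values shown sit.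

Compound 3 `Brc1ccc(-c2nnc(Cn3nnc4ccccc43)o2)cc1` has not yet been measured in this assay. It carries 4-bromophenyl in place of benzyl on an aromatic carbon. For the measured compounds named here, the only measured step, the one from compound 1 to compound 2, touches a different part of the molecule and its size is not readable, so it offers no direction beyond the scatter for the present change. On the numbers shown, compound 1 stands at the limit and nowhere else. Compound 3 is therefore expected to sit in the same region, with the step that the limit leaves unreadable from compound 1 to compound 3 understood as an estimate only. Compound 3 is estimated at 150000 nM, within a range from 50000 nM to 400000 nM.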

Compound 3, half-maximal cytotoxic concentration: > 100000 nM
Compound 3 ended at the assay's limit; the forecaster's own chance of this, stated with the estimate: 85%; the middle value is on the limit's open side.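

In this assay compound 3 gives > 100000 nM, which is a limit and not a number. No step from compound 1 to compound 3 can be read because both compounds rest on the same limit: the limit of > 100000 nM in this assay, at which 3 of the 3 values shown sit.

The compounds shown leave open whether benzyl and 4-bromophenyl on the shared core differ at all in this assay.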